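The compounds below may be only part of what the source reports. "The series", "measured", "known", "first", "only" and "open" are said of these compounds alone.

Compound 2 `Cc1ccccc1COc1c(-c2ccccc2)oc2cc(O)cc(O)c2c1=O` and compound 1 `O=c1c(OCc2ccccc2[N+](=O)[O-])c(-c2ccccc2)oc2cc(O)cc(O)c12` are both measured in an ADME assay on Huh-5-2 cells (Homo sapiens) for cytotoxicity, read by WST assay, with a stated time of 3 days; on this read-out lower numbers stand for higher toxicity in this test and higher numbers for lower toxicity in this test. In this assay compound 2 gives 55000 nM, and compound 1 gives 51000 nM. Compound 2 thus holds the higher of the two numbers, but the step of a 1.1-fold higher number from compound 1 to compound 2 (0.03 log units; within the scatter) is within the scatter, so the two values cannot be told apart.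

Compound 3 `N#Cc1cccc(COc2c(-c3ccccc3)oc3cc(O)cc(O)c3c2=O)c1` differs from compound 2 by 3-cyanophenyl in place of 2-methylphenyl on a saturated chain carbon bound to an oxygen on an aromatic ring. For the measured compounds named here, the only measured step that bears on this change is a 1.1-fold higher number from compound 1 to compound 2 (0.03 log units; within the scatter), in which a different substituent on the same benzyl group was exchanged without any visible effect on this assay. The change from compound 2 to compound 3 again exchanges one substituent on that benzyl group, now with a nitrile in place of a methyl, and nothing in the two measured numbers suggests that this assay responds to such a change.

Compound 3 is therefore expected to stay close to compound 2, with a step of about a 1.0-fold lower number from compound 2 to compound 3 (0.02 log units; within the scatter) that should be within the scatter. The estimate for compound 3 in this assay is 53000 nM, with a range from 25000 nM to 110000 nM.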

Compound 3, half-maximal cytotoxic concentration: 21000 nM
For compound 3 the middle estimate is 2.5-fold (0.40 log units) above the measured one; the whole stated range lies above it.
By their numbers in this assay, from the lowest: compound 3; then compounds 1 and 2 (each within the scatter of the next).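

The group on the saturated chain carbon bound to an oxygen on an aromatic ring turns out to matter in this assay, since the exchange for 3-cyanophenyl gives a 2.6-fold lower number from compound 2 to compound 3 (0.42 log units; beyond the scatter) and a 2.4-fold lower number from compound 1 to compound 3 (0.39 log units; beyond the scatter), both modest, whereas the earlier exchange of 2-nitrophenyl for 2-methylphenyl gave only a 1.1-fold higher number from compound 1 to compound 2 (0.03 log units; within the scatter). Compound 3 therefore stands apart from both earlier compounds as the one with the highest toxicity in this test, and the position is not as indifferent as that first pair suggested. Nothing available here explains the shift.

The change from 2-methylbenzyl to 3-cyanobenzyl alters both the group and the number it carries in the name, so the compounds shown cannot separate the nitrile itself from where it stands; 2-cyanophenyl and 3-methylphenyl would divide the two. Going by these compounds, it also remains open whether the unsubstituted benzyl group, or an amine or a carboxylic acid on that ring, would keep the number near that of compound 3 or return it to the level of compounds 1 and 2.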